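Step from compound 3 to compound 4 in the series

A few compounds are considered here, and "the series" means these few. Any claim that something is new, unique, unknown or untested is made for them only; others in the source may bear on it.

Three compounds of the shared core carry numbers in a functional assay on CHO-K1 cells for antagonist activity at adenosine receptor A1 (Homo sapiens), read by a beta-galactosidase reporter and cAMP accumulation, with stated times of 15 min and 6 h; on this read-out lower numbers stand for stronger inhibition and higher numbers for weaker inhibition. Compound 1 `Cc1ccc(-c2nc(N)c3ccsc3n2)o1` gives 493 nM, and compound 2 `Cc1ccc(-c2nc(N)c3cc(C(C)c4ccccc4)sc3n2)o1` gives 439 nM; the change a 1.1-fold lower number from compound 1 to compound 2 (0.05 log units; within the scatter), 1-phenylethyl in place of hydrogen on an aromatic carbon. Compound 3 `Nc1nc(-c2ccc(C3CC3)o2)nc2sc(Cc3ccccc3)cc12` gives 861 nM in this assay , which differs from compound 1 and from compound 2 only within the scatter, so no order among the three is established.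

Compound 4 `Cc1csc(-c2nc(N)c3cc(Cc4ccccc4)sc3n2)n1` differs from compound 3 by 4-methyl-1,3-thiazol-2-yl in place of 5-cyclopropylfuran-2-yl on an aromatic carbon. Going by the values given here, no measured step touches this position: the only step shown sits elsewhere on the core, and compounds 2 and 3 differ in two places at once, so their values show only that both lie within the scatter of each other. Among the compounds with values here, with no precedent, a step of no size beyond the scatter is expected, a 1.1-fold lower number from compound 3 to compound 4 (0.03 log units; within the scatter), with a wide range either way. Compound 4 is estimated at 800 nM in this assay , between 250 nM and 2600 nM.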

Compound 4, inhibition constant: 1490 nM
Compound 4: the middle estimate sits 1.9-fold (0.27 log units) below what was measured; the measured number falls inside the stated range.
By their numbers in this assay, from the lowest: compounds 2, 1, 3 and 4 (each within the scatter of the next, the first and the last beyond it).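

Going by these compounds alone, the first single-place reading at the aromatic carbon between two ring nitrogen atoms is 4-methyl-1,3-thiazol-2-yl in place of 5-cyclopropylfuran-2-yl, a 1.7-fold higher number from compound 3 to compound 4 (0.24 log units; within the scatter) in this assay. At this position, a five-membered aromatic ring with 2 hetero atoms and one with 1 hetero atom are therefore not separated by this read-out, even with the three-membered ring gone. Nothing measured here offers an explanation for this result.

As far as these compounds go, how 5-methylfuran-2-yl compares with either of these groups stays open, as compound 1 and compound 2 each differ from compound 4 in more than one place. Also open, from the compounds shown here alone, is whether a group without an aromatic ring on this carbon, such as an amine or a carboxylic acid, would move the number beyond the scatter in either direction.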